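A Methyl Group Added to Compound 2

A few compounds are considered here, and "the series" means these few. Any claim that something is new, unique, unknown or untested is made for them only; others in the source may bear on it.

Within the data shown here, in a functional assay on L78 cells (Homo sapiens) for antiproliferative activity, read by MTT assay, with a stated time of 72 h (a higher number here means a weaker inhibitor, a lower number a stronger inhibitor), compound 1 (`Cc1ccccc1N1CCN(C2=CC(=O)c3cccc(O)c3C2=O)CC1`) gives 15100 nM and compound 2 (`O=C1C=C(N2CCC(c3ccccc3)CC2)C(=O)c2c(O)cccc21`) gives 13400 nM on the numbers so far. These two values lie within the usual scatter of each other, so compound 2 stands level with compound 1.

Compound 3 (`Cc1ccccc1C1CCN(C2=CC(=O)c3cccc(O)c3C2=O)CC1`) has not yet been measured. It differs from compound 2 in one place, with methyl in place of hydrogen on an aromatic carbon, ortho to a large group (methyl in place of hydrogen on an aromatic carbon). The same change reads as phenyl to 2-methylphenyl.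

Among the measured compounds shown here, no pair of measured compounds isolates this change, so the data offer no direct precedent for it. Compound 1 already carries the 2-methylphenyl group and gives 15100 nM within the scatter of compound 2, although those two also differ elsewhere. The expected shift in this assay is therefore none beyond the scatter, with an estimated 1.0-fold lower number from compound 2 to compound 3 (0.01 log units; within the scatter) in either direction at most of little meaning. For compound 3 the estimated value is 13000 nM and it is expected to fall between 6500 nM and 26000 nM.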

Compound 3, half-maximal inhibitory concentration: 4400 nM
The estimate for compound 3 lay 3.0-fold (0.47 log units) above the measured number; the measured number lies below the stated range.
By their numbers in this assay, from the lowest: compound 3; then compounds 2 and 1 (each within the scatter of the next).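

In this assay, the change from phenyl to 2-methylphenyl gives a 3.0-fold lower number from compound 2 to compound 3 (0.48 log units; beyond the scatter). Among these compounds, this is the first step here that isolates a single change, and it shows that the number responds to what this aromatic carbon, ortho to a large group, carries. Compound 1 also bears the 2-methylphenyl group and gives 15100 nM, while compound 3 gives 4400 nM, so the group does not go with the lower number wherever it stands, and these two differ in the part that joins it to the shared core. No measurement shown here speaks to why the step occurs.

Going by these compounds, whether the lower number belongs to methyl itself or would also come with chloro, methoxy or ethyl on the same carbon remains open, as does what methyl would do elsewhere on that ring. On these data alone, it also remains open whether the step would recur with an amine or a carboxylic acid on that ring, and since this is one step in one cell line, its reach beyond compound 2 and compound 3 is unknown.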